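Benzyloxy imidazopyridine series: removal of a ring methyl

The source may hold more compounds than are shown below. What is called first, only, known or untested is meant among the compounds shown, and "the series" means these compounds.

Measured so far:
compound 1 `Cc1ccn2c(C)c(C)nc2c1OCc1ccccc1`: 92%
compound 2 `Cc1nc2c(OCc3ccccc3)cccn2c1N`: 99%

Compound 2 stands highest of the two numbers in a functional assay on the whole organism with Rattus norvegicus as the target, at a dose of 40 mg/kg by the intraperitoneal route (on this read-out higher numbers stand for more inhibition at the one dose given (going by the name of the read-out) and lower numbers for less inhibition), but compound 1 sits within the scatter of it, so the two cannot be ordered. For the measured compounds named here, no single-point step between them is known. Compound 3 `Nc1cnc2c(OCc3ccccc3)cccn12` keeps the amino group and the benzyloxy side chain of compound 2 and differs only by hydrogen in place of methyl on an aromatic carbon. Going by the values given here, with no measured step to go by, a small change in this assay is expected, in either direction, not beyond the scatter. For compound 3 a value of 90% is estimated, within 70% to 99%, a step of a number 9 percentage points lower from compound 2 to compound 3 (within the scatter).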

Compound 3, a percentage reported as inhibition, in the whole organism at one dose (the size of the read-out at that dose, not a potency): 32%
Compound 3: the middle estimate sits 58 percentage points above what was measured, outside the stated range (below it).
By their numbers in this assay, from the lowest: compound 3; then compounds 1 and 2 (each within the scatter of the next).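

In this assay, for the compounds shown here, the methyl on this aromatic carbon is not a neutral substituent: hydrogen in its place gives a number 67 percentage points lower from compound 2 to compound 3 (beyond the scatter), the first step beyond the scatter. With the amino group and the benzyloxy side chain kept, this single change separates high from low inhibition at the one dose. Nothing at hand explains the loss.

On these data alone, whether methyl itself is required remains open: ethyl, chlorine or methoxy on the same carbon would test this. Also open, as far as these compounds go, is whether the same change costs as much on the core of compound 1.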